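This account rests on a few compounds, and the source may have more. Where it says the series, first, only, none or still open, it means among the compounds named here.

Series notes, with two compounds measured and one pending. In a functional assay on C6 cells (Rattus norvegicus) for inhibition, read by sulforhodamine B assay, with a stated time of 72 h (a higher number here means that more compound is needed for the effect, a lower number that less compound is needed), compound 1 `CCC(=O)Oc1cccc2ccc(/C=C/c3ccccc3[N+](=O)[O-])nc12` gives 6300 nM as the half-maximal effective concentration. In this assay compound 2 `O=C(/C=C/c1ccc([N+](=O)[O-])o1)c1ccc(Br)cc1` gives 2700 nM and holds the lower of the two numbers, a gap beyond the usual scatter. For the measured compounds named here, these two compounds differ in more than one place, so no single-change step is available to calibrate the next comparison. Compound 3 `O=C(/C=C/c1ccc([N+](=O)[O-])o1)c1ccc(I)cc1` differs from compound 2 only by iodo in place of bromo on an aromatic carbon and nothing else changes. Going by the values given here, with no measured precedent for this exchange, the expectation is for no shift beyond the scatter and no firm direction. The expected change is a 1.1-fold lower number from compound 2 to compound 3 (0.03 log units; within the scatter) and it remains a small one. For compound 3 the estimated value is 2500 nM with an expected range of 1000 nM to 6000 nM in this reading.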

Compound 3, half-maximal effective concentration: 2100 nM
For compound 3 the middle estimate is 1.2-fold (0.08 log units) above the measured one, and the stated range covers the measured number.
By their numbers in this assay, from the lowest: compounds 3 and 2 (each within the scatter of the next); then compound 1.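

For the compounds shown here, the first single-change step falls on an aromatic carbon of a six-membered aromatic ring of carbon only, para to a large group. In this assay, iodo in place of bromo gives a 1.3-fold lower number from compound 2 to compound 3 (0.11 log units; within the scatter), so this read-out does not separate the two halogens at this position.

Still open, going by these compounds, is whether a group of another kind here, such as an amine, a carboxylic acid or a methoxy group, would move the number beyond the scatter. Also open is how the rest of the shared core of compound 2 and compound 3 contributes, since the compounds shown offer no single-change step away from this position. No measured evidence bears on this result, and the step stands without an explanation.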